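A few compounds are considered here, and "the series" means these few. Any claim that something is new, unique, unknown or untested is made for them only; others in the source may bear on it.

Measured compounds:
Compound 1 `Fc1ccc(-c2nc3sc(Cc4ccc(Cl)cc4)nn3c2Br)cc1` in an ADME assay on CCRF-CEM cells (Homo sapiens) for cytotoxicity, with a stated time of 72 h (on this read-out lower numbers stand for stronger inhibition and higher numbers for weaker inhibition), gives > 250000 nM, a limit of the assay.
Compound 2 `Clc1ccc(Cc2nn3c(Br)c(-c4ccc(Cl)cc4)nc3s2)cc1` gives > 250000 nM, again a limit.
Compound 3 `Clc1ccc(Cc2nn3c(Br)c(-c4ccc(Cl)cc4Cl)nc3s2)cc1` gives 106000 nM.

Compound 2 thus stands at the limit of > 250000 nM in this assay, at which 2 of the 3 values shown sit, and only compound 3 gives a number, seen in an at least 2.3-fold lower number from compound 2 to compound 3 (0.37 log units; beyond the scatter). Compound 4 `N#CSc1c(-c2ccc(Cl)cc2)nc2sc(Cc3ccc(Cl)cc3)nn12` differs from compound 2 by cyanosulfanyl in place of bromo on an aromatic carbon. Among the measured compounds shown here, none of the measured steps touches this position: a step that the two limits leave unreadable from compound 1 to compound 2 and an at least 2.3-fold lower number from compound 1 to compound 3 (0.37 log units; beyond the scatter) change only the aryl group. For the measured compounds named here, the account therefore has no measured step that bears on the change, and no shift beyond the scatter is predicted in this assay. Compound 4 is estimated at 200000 nM, between 60000 nM and 700000 nM, a step of an at least 1.2-fold lower number from compound 2 to compound 4 (0.09 log units; that floor lies within the scatter) that is expected, not measured.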

Compound 4, half-maximal inhibitory concentration: 30000 nM
Estimate against measurement, compound 4: 6.7-fold (0.82 log units) above, and the stated range ends above it.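

In this assay, among the compounds shown here, the bromo position, which no earlier step had touched, proves able to shift the read-out: cyanosulfanyl in place of bromo brings an at least 8.3-fold lower number from compound 2 to compound 4 (0.92 log units; beyond the scatter). Before this, only a change in the aryl group had given a readable shift. The true size of the new step stays unknown, since compound 2 gives only a limit: the limit of > 250000 nM in this assay, at which 2 of the 4 values shown sit.

As far as these compounds go, whether other groups here, such as an amine, a nitrile or a methylthio group, would shift the read-out as well remains open. So does whether the 2,4-dichlorophenyl change would add to this step.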